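This account rests on a few compounds, and the source may have more. Where it says the series, first, only, none or still open, it means among the compounds named here.

Two compounds share a core built around a six-membered aromatic ring with one nitrogen, each carrying a thiophen-3-yl group, a second aromatic ring and a furan-type ring. Compound 1 `Cc1cccc(-c2cc(-c3ccc(Cl)o3)cc(-c3ccsc3)n2)c1` and compound 2 `Cc1ccc(-c2cc(-c3ccoc3)cc(-c3ccsc3)n2)cc1` were both tested in an assay on isolated protein for inhibition of DNA topoisomerase 1 (Homo sapiens), tested at 100 uM; on this read-out lower numbers stand for a weaker effect and higher numbers for a stronger effect at the one concentration tested. In this assay compound 1 gives 7.5%, and compound 2 gives 13.2%. Compound 2 holds the higher of the two numbers, but its gap to compound 1 lies within the usual scatter of repeated measurements, so the two read-outs cannot be told apart. Compound 3 `Cc1ccc(-c2cc(-c3ccc(Cl)o3)cc(-c3ccsc3)n2)cc1` has not yet been measured. It differs from compound 2 in one place: 5-chlorofuran-2-yl in place of furan-3-yl on an aromatic carbon. Going by the values given here, the only measured pair, compound 1 and compound 2, differs in this ring and in another group at the same time, so no single-point step exists to guide a forecast. Because compound 1 gives 7.5% and compound 2 gives 13.2% in this assay, both low and close together, the expected step in this assay is small, with no direction beyond the scatter. For compound 3 the estimated inhibition is 10%, within a range from 2% to 20%. This corresponds to an expected step of a number 3.2 percentage points lower from compound 2 to compound 3 (within the scatter).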

Compound 3, a percentage reported as inhibition, at one concentration (the size of the read-out at that concentration, not a potency): 2.6%
For compound 3 the middle estimate is 7.4 percentage points above the measured one; the measured number falls inside the stated range.
By their numbers in this assay, from the lowest: compounds 3, 1 and 2 (each within the scatter of the next, the first and the last beyond it).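

In this assay, going by these compounds alone, the first single-place comparison at the aromatic carbon opposite the ring nitrogen shows that putting 5-chlorofuran-2-yl in place of furan-3-yl gives a number 10.6 percentage points lower from compound 2 to compound 3 (beyond the scatter), so this change has a readable, modest effect on the read-out. The second single-place comparison concerns the methyl group on the phenyl ring: 4-methylphenyl in place of 3-methylphenyl gives a number 4.9 percentage points lower from compound 1 to compound 3 (within the scatter), so this pair shows no separable difference between the two placements of the methyl group. Nothing measured here accounts for the lower number seen with the 5-chlorofuran-2-yl group.

The swap alters two features together, adding a chlorine and moving the point at which the furan ring is attached, so these compounds cannot show whether either feature alone accounts for the step. From the compounds shown here alone, it also remains open how a furan-2-yl group without chlorine, a 5-methylfuran-2-yl group, or a group of a different kind such as an amine or a carboxylic acid would read at this same position.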